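The source may report more compounds than this note shows. Statements on the series, on what has been measured and on what is new or still open speak of the compounds shown alone.

Measured compounds:
compound 1, `CCN(Cc1ccc2nc(C)[nH]c(=O)c2c1)c1ccc(C(=O)N[C@@H](CCC(=O)O)C(=O)O)c(C)c1`, 320 nM
compound 2, `C=CCN(Cc1ccc2nc(C)[nH]c(=O)c2c1)c1ccc(C(=O)N[C@@H](CCC(=O)O)C(=O)O)c(F)c1`, 76 nM

In an assay on isolated protein for inhibition of Thymidylate synthase (Mus musculus) (a higher number here means a weaker inhibitor, a lower number a stronger inhibitor), compound 2 gives 76 nM, the lowest of the two numbers recorded. For the measured compounds named here, its nearest neighbour is compound 1, which in this assay gives 320 nM, a higher number by a margin beyond the scatter; the two compounds differ from each other in more than one place, so no single step connects them.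

Compound 3, `Cc1nc2ccc(CN(CCN)c3ccc(C(=O)N[C@@H](CCC(=O)O)C(=O)O)c(F)c3)cc2c(=O)[nH]1`, has not yet been measured in this assay. It differs from compound 2 in one place: aminomethyl in place of vinyl on a saturated chain carbon bound to a nitrogen on an aromatic ring, which read one bond further out is allyl to 2-aminoethyl.

Going by the values given here, no measured pair shows this change, so the expected step rests on the structural difference alone. A weakening of inhibition is expected, moderate in size, and the step from compound 2 to compound 3 is estimated at a 3.3-fold higher number from compound 2 to compound 3 (0.52 log units; beyond the scatter). Compound 3 is therefore expected to give about 250 nM in this assay, within a range of 60 nM to 1000 nM.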

Compound 3, half-maximal inhibitory concentration: 11700 nM
The estimate for compound 3 lay 47-fold (1.67 log units) below the measured number, outside the stated range (above it).
By their numbers in this assay, from the lowest: compound 2; then compound 1; then compound 3.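

In this assay, the change from allyl to 2-aminoethyl, which puts aminomethyl in place of vinyl on a saturated chain carbon bound to a nitrogen on an aromatic ring, gives a 150-fold higher number from compound 2 to compound 3 (2.19 log units; beyond the scatter) and is a large loss of inhibition. Compounds 1 and 2 differ in more than one place and so could not isolate this position, whereas this single change shows that inhibition depends strongly on the group carried there, even though the heavy-atom count stays the same and the swap is one carbon for one nitrogen, with a hydrogen-bond donor and acceptor entering and a double bond leaving. Nothing available here accounts for the size of this loss.

The compounds shown leave open whether the loss belongs to the terminal amine itself or would also appear with a hydroxyl or a carboxylic acid at the end of the chain. They also leave open whether a longer chain carrying the amine, or a tertiary amine in its place, would recover any of the inhibition seen with compound 2.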